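The compounds below may be only part of what the source reports. "The series", "measured", "known", "first", "only" and "open" are said of these compounds alone.

In an assay on isolated protein for inhibition of receptor-type tyrosine-protein phosphatase C (Homo sapiens), read by spectrophotometry (on this read-out lower numbers stand for stronger inhibition and higher numbers for weaker inhibition), the three measured compounds share one core and differ only at an amide-type nitrogen. Compound 1 `O=C(COc1ccc2cc(C(O)(C(F)(F)F)C(F)(F)F)c(O)cc2c1)Nc1nc2ccccc2s1` gives 10900 nM. Compound 2 `Cc1ccc(S(=O)(=O)NNC(=O)COc2ccc3cc(C(O)(C(F)(F)F)C(F)(F)F)c(O)cc3c2)cc1` gives 16100 nM. Compound 3 `O=C(COc1ccc2cc(C(O)(C(F)(F)F)C(F)(F)F)c(O)cc2c1)NCc1ccc(F)cc1` reaches only the limit of > 20000 nM, so for compound 3 there is no number, only a floor (the limit of > 20000 nM in this assay, at which 1 of the 3 values shown sits). The measured steps are all small: a 1.5-fold higher number from compound 1 to compound 2 (0.17 log units; within the scatter), an at least 1.8-fold higher number from compound 1 to compound 3 (0.26 log units; that floor lies within the scatter) and an at least 1.2-fold higher number from compound 2 to compound 3 (0.09 log units; that floor lies within the scatter); none of them moves beyond the scatter, so compound 3 stands at the weak end only as far as a limit can place it.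

Compound 4 `O=C(COc1ccc2cc(C(O)(C(F)(F)F)C(F)(F)F)c(O)cc2c1)NC1CC1` takes the next step on the same nitrogen: cyclopropyl in place of 4-fluorobenzyl on an amide-type nitrogen. Every change tried so far at this position, from compound 1 through compound 3, left the numbers within the scatter of one another, and nothing among them suggests a shift in either direction for compound 4. Compound 4 is therefore expected to stay near the floor of compound 3, with a step that the limit leaves unreadable from compound 3 to compound 4, and its estimated value is 25000 nM within a range from 8000 nM to 70000 nM, with a fair chance that only a limit is reported again.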

Compound 4, half-maximal inhibitory concentration: > 20000 nM
Compound 4: only a limit was reported; the forecaster's own chance of this, stated with the estimate: 55%; the middle value does not contradict the limit.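

With cyclopropyl on the amide-type nitrogen, compound 4 gives only the limit > 20000 nM in this assay and no number, so the aromatic ring of 4-fluorobenzyl is not required for a compound to end at this limit. Set against the two compounds that have numbers, the change gives an at least 1.8-fold higher number from compound 1 to compound 4 (0.26 log units; that floor lies within the scatter) and an at least 1.2-fold higher number from compound 2 to compound 4 (0.09 log units; that floor lies within the scatter) and so, like the earlier changes at this nitrogen, shows no shift beyond the scatter. Compound 3 and compound 4 both carry only a limit, so the step between them cannot be read, and cyclopropyl and 4-fluorobenzyl cannot be ranked against each other: the limit of > 20000 nM in this assay, at which 2 of the 4 values shown sit.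

The compounds shown leave open how far compound 3 and compound 4 lie past that limit. They also leave open whether a carboxylic acid, a primary amine or a longer alkyl chain on this nitrogen would give a value beyond the scatter of the others.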